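The compounds below may be only part of what the source reports. "The series", "measured", "known", "first", "only" and "open" are said of these compounds alone.

Measured compounds and their growth-inhibition values:

Compound 1, `COc1cc(OC)cc(-c2ccc(-c3ccc(C(=N)N)c(F)c3)s2)c1`: 326 nM
Compound 2, `N=C(N)c1ccc(-c2ccc(-c3ccc(Cl)cc3)s2)cc1F`: 243 nM
Compound 3, `N=C(N)c1ccc(-c2ccc(-c3ccc(Cl)cc3)s2)cc1`: 207 nM

All three were tested in a functional assay on MOLT-4 cells (Homo sapiens) for inhibition, read by sulforhodamine B assay, with a stated time of 48 h; on this read-out lower numbers stand for stronger inhibition of growth and higher numbers for weaker inhibition of growth. Compound 1 and compound 2 share a large part of their structure but differ in more than one place; the difference between the two cores is not broken down here. In this assay compound 1 gives 326 nM and compound 2 gives 243 nM, and these two numbers lie within the usual scatter of one another, so nothing can be read from their difference.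

Compound 2 and compound 3 differ in one place only: hydrogen in place of fluoro on an aromatic carbon. This single change gave a 1.2-fold lower number from compound 2 to compound 3 (0.07 log units; within the scatter), a step that stays within the scatter and therefore shows no real effect of the change on growth inhibition in this pair.

Compound 4, `COc1cc(OC)cc(-c2ccc(-c3ccc(C(=N)N)cc3)s2)c1`, has not yet been measured. It stands to compound 1 exactly as compound 3 stands to compound 2: hydrogen in place of fluoro on an aromatic carbon. The place of the change is the same in both pairs, so the two changes are the same. Since the earlier step, a 1.2-fold lower number from compound 2 to compound 3 (0.07 log units; within the scatter), stayed within the scatter, the step from compound 1 to compound 4 is expected to be small as well, estimated at a 1.2-fold lower number from compound 1 to compound 4 (0.07 log units; within the scatter). On that basis compound 4 is expected to give about 280 nM in this assay, most likely between 140 nM and 560 nM.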

Compound 4, concentration for 50% growth inhibition: 1650 nM
The estimate for compound 4 lay 5.9-fold (0.77 log units) below the measured number; the whole stated range lies below it.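

In this assay, putting hydrogen in place of the fluoro on the core of compound 1 gave a 5.1-fold higher number from compound 1 to compound 4 (0.70 log units; beyond the scatter), so on this core the change weakens growth inhibition, while on the core of compound 2 the same change gave a 1.2-fold lower number from compound 2 to compound 3 (0.07 log units; within the scatter) and shows no real effect. The change therefore did not carry over from one core to the other with the same size: the same change on two cores in this assay, a 1.2-fold lower number (0.07 log units; within the scatter) from compound 2 to compound 3 and a 5.1-fold higher number (0.70 log units; beyond the scatter) from compound 1 to compound 4, 5.9-fold (0.77 log units) apart, beyond the scatter of two such steps. This shows that, in these two pairs, the result of removing the fluoro depends on the core that carries it, but the two cores differ in more than one place, so the data do not show which of those differences matters, and two pairs cannot give a rule for the whole series.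

The compounds shown hold only fluoro or hydrogen at this place on the ring, so what a methyl group, a hydroxyl group or a nitrile there would do on either core remains open. Going by these compounds, it also remains open whether cores carrying other groups, such as an amine or a carboxylic acid in place of the chloro or methoxy groups, would follow compound 1 and compound 4 or compound 2 and compound 3.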